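The compounds below may be only part of what the source reports. "The series", "measured", "known", "first", "only" and "open" are said of these compounds alone.

Measured compounds:
Compound 1 `C=CCNc1n[n+]([O-])c2ccccc2[n+]1[O-]`: 3000 nM
Compound 2 `[O-][n+]1nc(NC2CC2)[n+]([O-])c2ccccc21`: 1900 nM

Both compounds share one core and differ only in the small group carried on the ring nitrogen. In a functional assay on MOLT-4 cells (Homo sapiens) for cytotoxicity, read by MTT assay, with a stated time of 48 h (on this read-out lower numbers stand for stronger inhibition and higher numbers for weaker inhibition), compound 1 gives 3000 nM, and compound 2 gives 1900 nM. The step of a 1.6-fold lower number from compound 1 to compound 2 (0.20 log units; within the scatter) is within the scatter, so compound 2 stands beside compound 1 at essentially the same level, and neither can be called the stronger of the two.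

Compound 3 `CCNc1n[n+]([O-])c2ccccc2[n+]1[O-]` carries the change (ethyl in place of cyclopropyl on a nitrogen on an aromatic ring). For the measured compounds named here, the only measured step that bears on this position, a 1.6-fold lower number from compound 1 to compound 2 (0.20 log units; within the scatter), shows that swapping one small group for another there left the number within the scatter. On that basis the step of a 1.3-fold higher number from compound 2 to compound 3 (0.12 log units; within the scatter) is expected to stay within the scatter as well, with no clear direction. For compound 3 the estimated value in this assay is 2500 nM, with a range from 1000 nM to 6000 nM.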

Compound 3, half-maximal inhibitory concentration: 3300 nM
The estimate for compound 3 lay 1.3-fold (0.12 log units) below the measured number, and the stated range covers the measured number.
By their numbers in this assay, from the lowest: compounds 2, 1 and 3 (each within the scatter of the next).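

In this assay, closing the chain into a ring makes no readable difference at this position: ethyl in place of cyclopropyl gives a 1.7-fold higher number from compound 2 to compound 3 (0.24 log units; within the scatter), still within the scatter. The end of the chain tells the same story, since methyl in place of vinyl gives a 1.1-fold higher number from compound 1 to compound 3 (0.04 log units; within the scatter), so allyl, cyclopropyl and ethyl on this nitrogen all sit at one level, whether the group holds a ring, a double bond or neither. No data are given that could explain this flat picture.

The compounds shown leave open whether a much bulkier group on this nitrogen, such as a benzyl group or a longer chain, would move the number beyond the scatter. They also leave open what a chain ending in an amine or a carboxylic acid would do there.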